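Terminal amine variation on the chain: compound 3

This account rests on a few compounds, and the source may have more. Where it says the series, first, only, none or still open, it means among the compounds named here.

Measured so far in an assay on isolated protein (Cavia porcellus) with Sigma non-opioid intracellular receptor 1 (Homo sapiens) as the target, read by radioligand binding; on this read-out lower numbers stand for stronger inhibition and higher numbers for weaker inhibition:
compound 1 `CN(C)CCCCCCOc1ccc2oc(-c3ccccc3)cc(=O)c2c1`: 335 nM
compound 2 `O=c1cc(-c2ccccc2)oc2ccc(OCCCCCCN3CCCC(O)C3)cc12`: 77 nM

Compound 2 stands lowest of the two numbers in this assay. Within the data shown here, the only measured step is a 4.4-fold lower number from compound 1 to compound 2 (0.64 log units; beyond the scatter); it is the sole point of reference for the next change.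

Compound 3 `CCOC(=O)C1CCN(CCCCCCOc2ccc3oc(-c4ccccc4)cc(=O)c3c2)CC1` is not yet measured. Its change from compound 2 is 4-(ethoxycarbonyl)piperidin-1-yl in place of 3-hydroxypiperidin-1-yl on a saturated chain carbon, six bonds along the chain from an oxygen on an aromatic ring. The step from compound 1 to compound 2 bears on it only loosely: that step swapped an open-chain amine for a ring amine, while here the ring amine is kept and only its substituent changes, the hydrogen-bond donor leaving and an ester entering. Among the measured compounds shown here, no measured pair tests this kind of change, so no step beyond the scatter is expected, with a slight lean toward a higher number.

Compound 3 is therefore estimated at 110 nM, within 35 nM to 350 nM. That estimate corresponds to a 1.4-fold higher number from compound 2 to compound 3 (0.15 log units; within the scatter).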

Compound 3, half-maximal inhibitory concentration: 102 nM
Beside the measured number, compound 3's estimate is 1.1-fold (0.03 log units) above it; the range from low to high includes it.
By their numbers in this assay, from the lowest: compounds 2 and 3 (each within the scatter of the next); then compound 1.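

In this assay, a 1.3-fold higher number from compound 2 to compound 3 (0.12 log units; within the scatter): at this place on the chain, the hydroxyl of 3-hydroxypiperidin-1-yl can give way to the larger 4-(ethoxycarbonyl)piperidin-1-yl, with 0 hydrogen-bond donors, without a step beyond the scatter. Against the open-chain amine, a 3.3-fold lower number from compound 1 to compound 3 (0.52 log units; beyond the scatter), so both substituted piperidin-1-yl groups shown stand beyond the scatter from dimethylamino, and none of the three compounds goes against this. No evidence on hand explains either step.

On these data alone, it remains open whether an unsubstituted piperidin-1-yl or a morpholin-4-yl group on the same chain would fall with compound 2 and compound 3 or with compound 1. As far as these compounds go, the effect of a shorter or longer chain on these terminal amines also remains open.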